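This account rests on a few compounds, and the source may have more. Where it says the series, first, only, none or still open, it means among the compounds named here.

Compound 2 `COc1cc(Cl)cc(-c2nn(-c3cccc(NC(=O)Nc4ccc(Cl)c(Cl)c4)c3)cc2-c2ccncc2)c1` and compound 1 `O=C(Nc1cccc(-n2cc(-c3ccncc3)c(-c3cc(O)cc(Cl)c3)n2)c1)Nc1ccc(Cl)c(Cl)c1` share one core and differ only in a methyl in place of hydrogen on an oxygen on an aromatic ring. In a functional assay on OVCAR-3 cells (Homo sapiens) for inhibition, read by sulforhodamine B assay, with a stated time of 48 h (a higher number here means a weaker inhibitor, a lower number a stronger inhibitor), compound 2 gives 1560 nM, and compound 1 gives 1960 nM; the step of a 1.3-fold lower number from compound 1 to compound 2 (0.10 log units; within the scatter) leaves the two indistinguishable, so compound 2 has the lower of the two numbers without standing apart from compound 1. Compound 3 `COc1cc(Cl)cc(-c2nn(-c3cccc(NC(=O)c4cccc(C(F)(F)F)c4)c3)cc2-c2ccncc2)c1` is not yet measured; it keeps the methyl on oxygen of compound 2 and changes (3-(trifluoromethyl)phenyl in place of (3,4-dichlorophenyl)amino on a carbonyl carbon). Among the measured compounds shown here, no measured step touches this part of the molecule: the only step in hand, a 1.3-fold lower number from compound 1 to compound 2 (0.10 log units; within the scatter), concerns the oxygen substituent on the other side and is within the scatter, so it gives no guidance on the size or direction of the change at the carbonyl carbon. With nothing to lean on, the expectation for compound 3 is a number close to that of compound 2, the step of a 1.6-fold higher number from compound 2 to compound 3 (0.20 log units; within the scatter) carried with wide uncertainty, and compound 3 is estimated at 2500 nM with a range from 700 nM to 9000 nM.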

Compound 3, half-maximal inhibitory concentration: 7690 nM
For compound 3 the middle estimate is 3.1-fold (0.49 log units) below the measured one; the measured number falls inside the stated range.
By their numbers in this assay, from the lowest: compounds 2 and 1 (each within the scatter of the next); then compound 3.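

Among the compounds shown here, at the carbonyl carbon, 3-(trifluoromethyl)phenyl in place of (3,4-dichlorophenyl)amino gives the first step beyond the scatter in this assay, a 4.9-fold higher number from compound 2 to compound 3 (0.69 log units; beyond the scatter), whereas the change on the oxygen, a 1.3-fold lower number from compound 1 to compound 2 (0.10 log units; within the scatter), stays within it. This position therefore responds to substitution in a way the oxygen substituent did not show, and here the change goes toward weaker inhibition. The change removes the amino nitrogen with its hydrogen-bond donor and replaces both chlorines with trifluoromethyl in one step, and no measurement bears on why the number rises.

The compounds shown do not separate the amino nitrogen from the ring substituents as the source of the step. (3-(Trifluoromethyl)phenyl)amino on the same carbonyl carbon would keep the nitrogen and change only the ring substituents.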